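Fluoro in place of hydrogen on the benzoyl of compound 2

A few compounds are considered here, and "the series" means these few. Any claim that something is new, unique, unknown or untested is made for them only; others in the source may bear on it.

Measured compounds:
- compound 1, `COc1cccc(-c2nn(-c3ccccc3)cc2-c2ccnc(NCCCNC(=O)Nc3ccc(Cl)c(Cl)c3)c2)c1`: 2400 nM
- compound 2, `O=C(NCCCNc1cc(-c2cn(-c3ccccc3)nc2-c2cccc(O)c2)ccn1)c1ccccc1`: 1510 nM

Both numbers come from a functional assay on HCT-15 cells (Homo sapiens) for antiproliferative activity; a lower number here means a stronger inhibitor of growth, a higher number a weaker inhibitor of growth. Compound 2 has the lower of the two numbers, but its gap to compound 1 is within the usual scatter, so the two compounds cannot be told apart on these data. Compound 3, `O=C(NCCCNc1cc(-c2cn(-c3ccccc3)nc2-c2cccc(O)c2)ccn1)c1ccc(F)cc1`, keeps all of compound 2 and differs in one place only: fluoro in place of hydrogen on an aromatic carbon. Among the compounds with values here, no pair of measured compounds carries this change, so there is no measured step to lean on. A single fluorine on the benzoyl ring is expected to move the value in this assay by no more than the scatter, in no particular direction. The estimate for compound 3 is therefore 1300 nM, with a range of 500 nM to 3500 nM. This estimate means a step of a 1.2-fold lower number from compound 2 to compound 3 (0.07 log units; within the scatter), expected to stay within the scatter.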

Compound 3, concentration for 50% growth inhibition: 1770 nM
Beside the measured number, compound 3's estimate is 1.4-fold (0.13 log units) below it; measured number inside the range.
By their numbers in this assay, from the lowest: compounds 2, 3 and 1 (each within the scatter of the next).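

Within the data shown here, compound 2 and compound 3 give the first pair that differs in one place, so the benzoyl ring can now be read on its own. In this assay the change from phenyl to 4-fluorophenyl gives a 1.2-fold higher number from compound 2 to compound 3 (0.07 log units; within the scatter) and so does not separate fluoro from hydrogen at this ring carbon. No measurement at hand speaks to what the fluoro does at this position.

Going by these compounds, whether an amine, a carboxylic acid or a longer chain in place of this fluoro would give a step beyond the scatter remains open, as does the reading for fluoro on the other carbons of this ring. Compound 1 differs from compound 2 in more than one place, so the separate contributions of its groups also remain unresolved.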